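Homopiperazinyl pyridines at the alpha4/beta2 receptor: removing the bromo

The source may hold more compounds than are shown below. What is called first, only, known or untested is meant among the compounds shown, and "the series" means these compounds.

Measured so far:
compound 1 `Clc1ncc(N2CCCNCC2)cc1Br`, 57.5 nM
compound 2 `C=COc1cc(N2CCCNCC2)cnc1Br`, 110 nM

In a functional assay on HEK293 cells for agonist activity at Neuronal acetylcholine receptor; alpha4/beta2 (Homo sapiens), read by FLIPR and calcium flux (on this read-out higher numbers stand for an effect only at larger amounts of compound and lower numbers for an effect already at smaller amounts), compound 1 gives 57.5 nM. In the same assay compound 2 gives 110 nM, the higher of the two numbers; the gap to compound 1 lies within the scatter, so no order between them can be read.

Compound 3 `C=COc1cncc(N2CCCNCC2)c1` differs from compound 2 by hydrogen in place of bromo on an aromatic carbon. Going by the values given here, no step between measured compounds tells what such a change does here. The expected step from compound 2 to compound 3 is a 2.0-fold higher number from compound 2 to compound 3 (0.30 log units; within the scatter), a modest rise in the number. The expected value for compound 3 is 220 nM, with a range from 60 nM to 800 nM.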

Compound 3, half-maximal effective concentration: 1100 nM
Compound 3: middle estimate off by 5.0-fold (0.70 log units), on the low side, outside the stated range (above it).
By their numbers in this assay, from the lowest: compounds 1 and 2 (each within the scatter of the next); then compound 3.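

In this assay, going by these compounds alone, the bromo next to the ring nitrogen and ortho to the vinyloxy group cannot be dropped without cost: hydrogen in its place gives a 10-fold higher number from compound 2 to compound 3 (1.00 log units; beyond the scatter) and this is the first step to read this position. Nothing available here gives a reason for the size of this step.

As far as these compounds go, whether chloro, methyl or a nitrile on this carbon would keep the number close to that of compound 2 stays open. So does whether the bromo counts for as much when methoxy stands in place of the vinyloxy group.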